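This account rests on a few compounds, and the source may have more. Where it says the series, first, only, none or still open, it means among the compounds named here.

Measured so far in a functional assay on HEK293 cells for antagonist activity at metabotropic glutamate receptor 5 (Homo sapiens), read by FLIPR and calcium flux; on this read-out lower numbers stand for stronger inhibition and higher numbers for weaker inhibition:

Compound 1, `N#Cc1cccc(C(=O)NC2CCCC(NC(=O)c3ccccn3)C2)c1`, gives 531 nM.
Compound 2, `CN(C)c1cccc(C(=O)N[C@H]2CCC[C@H](NC(=O)c3cccc(Cl)c3)C2)c1`, gives only > 10000 nM, which is a limit of this assay and not a number.
Compound 3, `O=C(N[C@H]1CCC[C@H](NC(=O)c2ccccn2)C1)c1ccccn1`, gives 1150 nM.

Compound 2 therefore stands at the weakest end of what is shown: its value is the limit described in the limit of > 10000 nM in this assay, at which 1 of the 3 values shown sits, so the only thing known is that its inhibition is too weak for this assay to return a number. Compound 1 and compound 3 both sit well inside the measurable range, and the two share a pyridin-2-yl amide on the same core.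

The not yet measured compound 4, `O=C(N[C@H]1CCC[C@H](NC(=O)c2cccc(Cl)c2)C1)c1cccnc1`, differs from compound 2 in a single place: pyridin-3-yl in place of 3-(dimethylamino)phenyl on a carbonyl carbon. Going by the values given here, no measured pair shows this exact exchange, so no measured step can be pointed to for its size. Since compound 2 gives only a limit, the true size of the step from compound 2 to compound 4 cannot be known even after measurement; what can be expected is that compound 4 moves into the measurable range, a gain in this assay estimated at about an at least 3.3-fold lower number from compound 2 to compound 4 (0.52 log units; beyond the scatter). On that basis compound 4 is expected to give roughly 3000 nM in this assay, with a likely range from 800 nM to 10000 nM.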

Compound 4, half-maximal inhibitory concentration: 612 nM
For compound 4 the middle estimate is 4.9-fold (0.69 log units) above the measured one, outside the stated range (below it).
By their numbers in this assay, from the lowest: compounds 1, 4 and 3 (each within the scatter of the next, the first and the last beyond it). At a limit, above all of these: compound 2.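

In this assay compound 2 gives > 10000 nM, which is a limit of the assay and not a number. Compounds 2 and 4 form the only pair shown that differs in one place, and they show that the group on this carbonyl carbon, whose other neighbour is an amide-type nitrogen, can decide whether the assay returns a number at all: with the rest of the structure unchanged, pyridin-3-yl in place of 3-(dimethylamino)phenyl gives an at least 16-fold lower number from compound 2 to compound 4 (1.21 log units; beyond the scatter). This size is only a lower bound on the true step, since one end of it rests on a limit: the limit of > 10000 nM in this assay, at which 1 of the 4 values shown sits.

The exchange replaces 9 heavy atoms with 6 and also moves the nitrogen from the dimethylamino group into the ring, so the compounds shown cannot tell which of these differences matters. On these data alone, an unsubstituted phenyl ring or a 3-methoxyphenyl group at this position, with the rest of compound 4 kept, would help separate them, and how far the gain depends on the 3-chlorophenyl amide on the other side of the core also remains open.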